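The compounds below may be only part of what the source reports. "The series", "measured", "known", "first", "only" and "open" are said of these compounds alone.

Measured in an ADME assay on Caco-2 cells (Homo sapiens) for permeability, read by LC-MS, with a stated time of 95 min; a higher number here means that the compound crosses the layer faster, a lower number that the compound crosses the layer more slowly:
- compound 1 `N#Cc1cc(NS(=O)(=O)c2ccc(NC(=O)N3CCOCC3)cc2)ccc1Oc1ccc(Cl)c(C(F)(F)F)c1`: 3.8 10^-6 cm/s
- compound 2 `CC(=O)NCc1ccc(S(=O)(=O)Nc2ccc(Oc3ccc(Cl)c(C(F)(F)F)c3)c(C#N)c2)cc1`: 1.1 10^-6 cm/s

Among the measured compounds shown here, of these two compounds, compound 2 has the lower number at 1.1 10^-6 cm/s, and the only comparison available is compound 1 at 3.8 10^-6 cm/s. The next compound, compound 3 `CC(=O)N(C)c1ccc(S(=O)(=O)Nc2ccc(Oc3ccc(Cl)c(C(F)(F)F)c3)c(C#N)c2)cc1`, has the same atoms as compound 2, joined differently. It carries acetyl(methyl)amino in place of acetamidomethyl on an aromatic carbon, para to a large group: acetyl(methyl)amino in place of acetamidomethyl on an aromatic carbon.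

For the measured compounds named here, only one measured step bears on this position: a 3.5-fold lower number from compound 1 to compound 2 (0.54 log units; beyond the scatter). That modest step, which lies beyond the scatter, replaced ((morpholin-4-yl)carbonyl)amino with acetamidomethyl. Going by the values given here, it does not measure the present exchange, and no pair of compounds yet does. It only indicates the size of change seen so far when this substituent is replaced. In this assay, a step of similar or smaller size is therefore expected, leaning towards a higher number, though a result within the scatter would not be surprising.

The estimated change is a 2.0-fold higher number from compound 2 to compound 3 (0.30 log units; within the scatter). Compound 3 is expected to give 2.2 10^-6 cm/s, with an estimated range of 0.9 10^-6 cm/s to 5 10^-6 cm/s.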

Compound 3, apparent permeability: 4.4 10^-6 cm/s
For compound 3 the middle estimate is 2.0-fold (0.30 log units) below the measured one; measured number inside the range.
By their numbers in this assay, from the lowest: compound 2; then compounds 1 and 3 (each within the scatter of the next).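

In this assay, the position proves sensitive to how the same atoms are joined: acetyl(methyl)amino in place of acetamidomethyl gives a 4.0-fold higher number from compound 2 to compound 3 (0.60 log units; beyond the scatter), so this change alters the read-out with no change in the group's heavy atoms. Against ((morpholin-4-yl)carbonyl)amino, the same group gives a 1.2-fold higher number from compound 1 to compound 3 (0.06 log units; within the scatter), which leaves compound 1 and compound 3 indistinguishable and compound 2 as the one apart from them, so the step seen earlier from compound 1 to compound 2 is now matched by a step of similar size back up from compound 2 to compound 3. Nothing measured here accounts for the step between compound 2 and compound 3.

The exchange both moves the nitrogen onto the aromatic carbon and removes the amide hydrogen, and these compounds do not separate the two; (N-methylacetamido)methyl or a plain acetamido group at this place would do so. From the compounds shown here alone, how an amine or a carboxylic acid on this aromatic carbon would compare with these three groups also remains open.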